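Two Measured Sulfamates and One Expectation

The source may report more compounds than this note shows. Statements on the series, on what has been measured and on what is new or still open speak of the compounds shown alone.

Compound 1, `CCN(Cc1ccccc1)c1cccc(C(=O)N2CCc3ccc(OS(N)(=O)=O)cc3C2)c1`: 69%
Compound 2, `CCN(Cc1ccccn1)c1ccc(C(=O)N2CCc3ccc(OS(N)(=O)=O)cc3C2)cc1`: 87.7%

In an assay on HEK293 cells for inhibition of Steryl-sulfatase (Homo sapiens), tested at 1 uM (a lower number here means a weaker effect, a higher number a stronger effect of the compound at the concentration tested), compound 2 stands highest of the two numbers; its nearest neighbour, compound 1, lies lower by a margin beyond the usual scatter. Compound 3, `CN(CCCN1CCCCC1)c1ccc(C(=O)N2CCc3ccc(OS(N)(=O)=O)cc3C2)cc1`, is not yet measured. It differs from compound 2 in one place: methyl(3-(piperidin-1-yl)propyl)amino in place of ethyl((pyridin-2-yl)methyl)amino on an aromatic carbon. No measured pair isolates this change, so its size is not known from the data shown. The step of a number 9.7 percentage points lower from compound 2 to compound 3 (within the scatter) is expected to be small, downward if anything, and not beyond the scatter. In this assay compound 3 is estimated at 78%, with a range from 55% to 92%.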

Compound 3, a percentage reported as inhibition, at one concentration (the size of the read-out at that concentration, not a potency): 40.7%
Compound 3: the middle estimate sits 37.3 percentage points above what was measured; measured number below the stated range.
By their numbers in this assay, from the lowest: compound 3; then compound 1; then compound 2.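

In this assay, putting methyl(3-(piperidin-1-yl)propyl)amino in place of ethyl((pyridin-2-yl)methyl)amino on this aromatic carbon gives a number 47 percentage points lower from compound 2 to compound 3 (beyond the scatter). The read-out at this position therefore depends strongly on the amino substituent, even though the two groups are close in heavy-atom count and match in hydrogen-bond donors and acceptors. No accompanying measurement bears on the reason for the drop. The compounds shown leave open which part of the exchange carries the step: the ring, the chain or the groups on the nitrogen. They also leave open how a morpholine in place of the piperidine, or a shorter ethyl linker, would read.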